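The compounds below may be only part of what the source reports. "The series", "measured", "known", "first", "only" and "open" are said of these compounds alone.

Measured so far in the series:
compound 1 `CC(C)CN(Cc1ccccc1C(F)(F)F)S(=O)(=O)c1ccc2c(c1)C(O)CC(C1CCOCC1)O2` — 4.23
compound 2 `CCc1ccc(N(CC(C)C)S(=O)(=O)c2ccc3c(c2)C(OC2CCCCC2)CC(C2CCOCC2)O3)cc1` — 6.28
compound 3 `CCc1ccc(N(CC(C)C)S(=O)(=O)c2ccc3c(c2)C(O)CC(C(C)C2CCOCC2)O3)cc1` — 5.04

In a physicochemical assay for lipophilicity, at pH 7.4 (a lower number here means a more polar compound, a higher number a more lipophilic compound), compound 3 stands second highest of the three numbers: compound 1 sits lower and compound 2 higher, both gaps beyond the usual scatter. Going by the values given here, no pair of measured compounds differs in a single place, so no measured step is available to calibrate the next change.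

Compound 4 `CCc1ccc(N(CC(C)C)S(=O)(=O)c2ccc3c(c2)C(O)CC(C2CCNCC2)O3)cc1` remains to be measured in this assay. It differs from compound 3 as follows: piperidin-4-yl in place of 1-(oxan-4-yl)ethyl on a saturated ring carbon. Among the compounds with values here, with no comparable measured step, the expected shift rests on the structural change alone; a large downward step is expected, a number 2.44 log units lower from compound 3 to compound 4 (beyond the scatter), well beyond the scatter. Compound 4 is estimated at 2.6, with a range from 1.8 to 3.4.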

Compound 4, distribution coefficient: 1.04
The estimate for compound 4 lay 1.56 log units above the measured number, and the stated range ends above it.
By their numbers in this assay, from the lowest: compound 4; then compound 1; then compound 3; then compound 2.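

In this assay, going by these compounds alone, piperidin-4-yl in place of 1-(oxan-4-yl)ethyl on the saturated ring carbon gives a number 4.00 log units lower from compound 3 to compound 4 (beyond the scatter) and supplies the first single-place step. This shows that a change at this position alone can shift the read-out by a large amount, and compound 4 now holds the lowest number of the four. Nothing available bears on the reason for this step.

The step combines a change of ring hetero atom with removal of the ethyl link, and the compounds shown do not separate the two. Oxan-4-yl or 1-(piperidin-4-yl)ethyl at this position would divide the step between them.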